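The compounds below may be only part of what the source reports. "The series", "measured", "known", "first", "only" and "open" are said of these compounds alone.

Of the compounds shown here, three that share one core have been measured in a functional assay on CHO cells with adenosine receptor A1 (Homo sapiens) as the target, read by cAMP accumulation and immunoassay, with a stated time of 6 min, tested at 1 uM; on this read-out higher numbers stand for a weaker effect at the one concentration tested and lower numbers for a stronger effect. Compound 1 `Nc1scc(CN2CCN(c3ccc(Cl)cc3Cl)CC2)c1C(=O)c1ccc(Cl)cc1` gives -54%. Compound 2 `Nc1scc(CN2CCN(c3ccc(F)cc3Cl)CC2)c1C(=O)c1ccc(Cl)cc1` gives -39%. Compound 3 `Nc1scc(CN2CCN(c3cccnc3)CC2)c1C(=O)c1ccc(Cl)cc1` gives -2.7%, the highest number of the three, so its effect at the single concentration is the weakest; the steps of a number 51.3 percentage points higher from compound 1 to compound 3 (beyond the scatter) and a number 36.3 percentage points higher from compound 2 to compound 3 (beyond the scatter) both lie beyond the scatter. Compound 4 `Nc1scc(CN2CCN(c3ccc(F)cc3F)CC2)c1C(=O)c1ccc(Cl)cc1` differs from compound 3 in one place: 2,4-difluorophenyl in place of pyridin-3-yl on an amine nitrogen in a ring. Among the compounds with values here, this change runs the earlier steps backwards, since a number 51.3 percentage points higher from compound 1 to compound 3 (beyond the scatter) and a number 36.3 percentage points higher from compound 2 to compound 3 (beyond the scatter) show that pyridin-3-yl in place of 2,4-dichlorophenyl or 2-chloro-4-fluorophenyl went with a much higher number. Among the phenyl compounds, a number 15 percentage points higher from compound 1 to compound 2 (beyond the scatter) shows that fluoro in place of chloro went with a modestly higher number, so a ring with two fluorines may sit somewhat higher than compound 2. In this assay compound 4 is therefore expected to give -25%, between -45% and -5%, a large downward step of a number 22.3 percentage points lower from compound 3 to compound 4 (beyond the scatter).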

Compound 4, a percentage reported as activity, at one concentration (the size of the read-out at that concentration, not a potency): -66%
Compound 4: middle estimate off by 41 percentage points, on the high side; measured number outside the range, below it.
By their numbers in this assay, from the lowest: compound 4; then compound 1; then compound 2; then compound 3.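

In this assay the 2,4-difluorophenyl group of compound 4 gives the lowest number of the four, and its change from pyridin-3-yl goes with a number 63.3 percentage points lower from compound 3 to compound 4 (beyond the scatter) in this position on the amine nitrogen. Replacing 2,4-dichlorophenyl with it goes with a number 12 percentage points lower from compound 1 to compound 4 (beyond the scatter) and so reaches lower than the two-chlorine ring, while fluoro in place of chloro has no single direction here: one such swap goes with a number 15 percentage points higher from compound 1 to compound 2 (beyond the scatter) and the other with a number 27 percentage points lower from compound 2 to compound 4 (beyond the scatter) on a different aromatic carbon. Nothing available explains why the same kind of swap moves the number in opposite directions.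

Going by these compounds, it remains open how a ring with a single fluoro, or with methoxy or trifluoromethyl in place of the fluorines, would behave. Also open, on these data alone, is whether adding fluoro to the pyridin-3-yl ring would bring its number down.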